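This account rests on a few compounds, and the source may have more. Where it says the series, first, only, none or still open, it means among the compounds named here.

Measured in a functional assay on MCF7 cells (Homo sapiens) for antiproliferative activity, read by sulforhodamine B assay, with a stated time of 48 h; a lower number here means a stronger inhibitor, a higher number a weaker inhibitor:
- compound 1 `COc1cccc(/C=C/C(=O)/C=C(O)/C=C/c2cccc(OC)c2OC)c1OC`: > 50000 nM, a limit
- compound 2 `COc1cc(OC)c(C=C(C(=O)/C=C/c2cccc(OC)c2OC)C(=O)/C=C/c2cccc(OC)c2OC)c(OC)c1`: 720 nM

Among the compounds with values here, compound 2 holds the only true number in this assay. Compound 3 `COc1cccc(/C=C/C(=O)C(=Cc2ccc(OC)c(OC)c2OC)C(=O)/C=C/c2cccc(OC)c2OC)c1OC` has 2,3,4-trimethoxyphenyl in place of 2,4,6-trimethoxyphenyl on a double-bonded chain carbon bound to a double-bonded chain carbon. Within the data shown here, no measured step covers this change, so the expectation rests on compound 2 alone, at 720 nM. A small weakening, within the usual scatter, is expected: a 1.7-fold higher number from compound 2 to compound 3 (0.22 log units; within the scatter). For compound 3 the estimated value is 1200 nM, with an expected range of 350 nM to 5000 nM.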

Compound 3, half-maximal inhibitory concentration: 380 nM
The estimate for compound 3 lay 3.2-fold (0.50 log units) above the measured number, within the range that was stated.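

In this assay, 2,3,4-trimethoxyphenyl in place of 2,4,6-trimethoxyphenyl on a double-bonded chain carbon bound to a double-bonded chain carbon gives a 1.9-fold lower number from compound 2 to compound 3 (0.28 log units; within the scatter), so the two compounds cannot be told apart. This place in the series therefore accepts both arrangements of the three methoxy groups, a point that compound 2 alone could not show. Nothing at hand gives a cause for this step.

Open, from the compounds shown here alone, is whether the same place accepts an unsubstituted phenyl or a group carrying an amine. Also open, going by these compounds, is whether the match between these two arrangements holds in other cell lines.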